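Swapping the Chain on Compound 2 for a Carbamoyl Group

A few compounds are considered here, and "the series" means these few. Any claim that something is new, unique, unknown or untested is made for them only; others in the source may bear on it.

Three compounds have been measured so far:
compound 1, `CC(C)=CCC/C(C)=C/CC1Cc2c(O)cc(=O)n(CCCO)c2CC1(C)C`, 0%;
compound 2, `CC(C)=CCC/C(C)=C/COc1cc(=O)n(CCCO)c2c1CC(CC=C(C)C)C(C)(C)C2`, 18.4%;
compound 3, `CC(C)=CCC1Cc2c(OCCCNS(=O)(=O)c3ccc(Br)cc3)cc(=O)n(CCCO)c2CC1(C)C`, 3.7%.

These numbers come from a functional assay on PANC-1 cells (Homo sapiens) for inhibition, read by MTT assay, with a stated time of 24 h, tested at 10 uM; a higher number here means more inhibition at the concentration tested (going by the name of the read-out), a lower number less inhibition. Among the three, compound 2 gives the highest number; the nearest is compound 3, whose value lies lower by more than the usual scatter, and compound 1 lies furthest away, also beyond the scatter. Compound 2 therefore stands alone at the top of this small set, while the other two sit near the bottom of the scale.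

Compound 4, `CC(C)=CCC1Cc2c(OC(=O)Nc3ccccc3F)cc(=O)n(CCCO)c2CC1(C)C`, has not yet been measured. It differs from compound 2 in one place: (2-fluorophenyl)carbamoyl in place of 3,7-dimethylocta-2,6-dien-1-yl on an oxygen on an aromatic ring. Only what hangs from that oxygen changes; the shared core stays the same.

For the measured compounds named here, no step between two measured compounds that differ in one place is available, so there is no directly comparable pair to lean on. What can be seen is that compound 1, where that oxygen carries no such group, gives 0%, and compound 3, carrying a different substituent there, gives 3.7%, both well below compound 2. On that basis the step is expected to run downward, as a number 11.4 percentage points lower from compound 2 to compound 4 (beyond the scatter), beyond the scatter. Compound 4 is therefore estimated to give 7%, within a range from 0% to 22%.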

Compound 4, a percentage reported as inhibition, at one concentration (the size of the read-out at that concentration, not a potency): 0%
Compound 4: middle estimate off by 7 percentage points, on the high side, within the range that was stated.
By their numbers in this assay, from the lowest: compounds 1, 4 and 3 (each within the scatter of the next); then compound 2.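

In this assay, for the compounds shown here, this is the first pair that changes only what hangs from this oxygen: putting (2-fluorophenyl)carbamoyl in place of 3,7-dimethylocta-2,6-dien-1-yl gives a number 18.4 percentage points lower from compound 2 to compound 4 (beyond the scatter), and compound 4 reads 0%. Both groups have 10 heavy atoms, so that count alone cannot account for the step; the entering group instead brings an aromatic ring, a nitrogen, a fluorine, and a hydrogen-bond donor and acceptor, and this single pair cannot show which of these differences matters. No measurement here explains why the number moves.

On these data alone, it remains open whether the drop follows from the carbamoyl link or from the 2-fluorophenyl ring, and a plain phenylcarbamoyl group or a benzyl group on the same oxygen would help separate the two. As far as these compounds go, it is also open how much of the number seen for compound 2 depends on the length of its chain, a question that a butyl or hexyl chain on this oxygen could address.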